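A Chloro Added to Compound 2

This account rests on a few compounds, and the source may have more. Where it says the series, first, only, none or still open, it means among the compounds named here.

- Compound 1 `CN(Cc1ccccc1)S(=O)(=O)c1ccc(NC(=O)NCc2ccncc2)cc1` gives 4510 ng.h/mL
- Compound 2 `O=C(NCc1cn[nH]c1)Nc1ccc(S(=O)(=O)c2ccccc2)cc1` gives 9340 ng.h/mL

Both numbers come from an ADME assay on the whole organism (Mus musculus) for pharmacokinetics, at a dose of 10 mg/kg by the oral route (a lower number here means less compound in the circulation, a higher number more compound in the circulation at the dose given), and they are the only two measured so far. Compound 2 stands highest of the two, and its gap to compound 1 lies beyond the usual scatter. The two compounds differ in more than one place, so their gap cannot be tied to any single structural change.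

Compound 3 (`O=C(NCc1cn[nH]c1)Nc1ccc(S(=O)(=O)c2ccc(Cl)cc2)cc1`) is the next to be measured. It keeps all of compound 2 except for one place (chloro in place of hydrogen on an aromatic carbon). The change turns phenyl into 4-chlorophenyl, para to a large group.

Going by the values given here, no measured pair shows what this change does in this assay so the data offer no guide to direction. The starting point for compound 3 is therefore compound 2 at 9340 ng.h/mL and no shift beyond the scatter is expected. The expected step is a 1.0-fold lower number from compound 2 to compound 3 (0.02 log units; within the scatter) and it is only an estimate. Compound 3 is expected at 9000 ng.h/mL with 3000 ng.h/mL to 25000 ng.h/mL as the estimated range.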

Compound 3, area under the concentration-time curve: 54500 ng.h/mL
Compound 3: the middle estimate sits 6.1-fold (0.78 log units) below what was measured; measured number outside the range, above it.
By their numbers in this assay, from the lowest: compound 1; then compound 2; then compound 3.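

In this assay, putting chloro in place of hydrogen on this aromatic carbon, which turns phenyl into 4-chlorophenyl, gives a 5.8-fold higher number from compound 2 to compound 3 (0.77 log units; beyond the scatter), so this position clearly matters for how much compound reaches the circulation after an oral dose. Going by these compounds alone, this is the first effect that can be tied to a single structural change, as compound 1 and compound 2 differ in more than one place, and it shows that adding just one heavy atom, a chlorine, can shift this read-out well beyond the usual scatter. Nothing measured here says why the number rises with this change.

This single pair cannot show whether the rise is specific to chloro or would also appear with another group in the same place, such as fluoro, methyl, methoxy or a nitrile. It also leaves open whether chloro would have a similar effect on a different core, such as that of compound 1, so the step holds only for the pair of compound 2 and compound 3.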